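The compounds below may be only part of what the source reports. "The series", "measured", "known", "first", "only" and "open" are said of these compounds alone.

Measured in an ADME assay on HepG2 cells (Homo sapiens) for cytotoxicity, read by MTT assay, with a stated time of 72 h; on this read-out higher numbers stand for lower toxicity in this test and lower numbers for higher toxicity in this test:
- Compound 1 `CCN(CC)c1ccc(-c2cc(Cl)cn3c([N+](=O)[O-])c(CS(=O)(=O)c4ccccc4)nc23)cc1`: > 15600 nM (a limit of the assay)
- Compound 2 `O=[N+]([O-])c1c(CS(=O)(=O)c2ccccc2)nc2c(-c3ccc(CO)cc3)cc(Cl)cn12`: 13100 nM

Among the measured compounds shown here, compound 2 at 13100 nM holds the only actual number in this assay so far. Compound 1 stands at the limit of > 15600 nM in this assay, at which 1 of the 2 values shown sits. Compound 3 `O=[N+]([O-])c1c(CS(=O)(=O)c2ccccc2)nc2c(-c3cccc(CO)c3)cc(Cl)cn12` has 3-(hydroxymethyl)phenyl in place of 4-(hydroxymethyl)phenyl on an aromatic carbon, with the same atoms joined differently: 3-(hydroxymethyl)phenyl in place of 4-(hydroxymethyl)phenyl on an aromatic carbon.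

For the measured compounds named here, one measured step bears on this, and only indirectly: an at least 1.1-fold lower number from compound 1 to compound 2 (0.07 log units; that floor lies within the scatter). It swaps a different pair of groups and rests on a limit, so it gives no measure of what moving the hydroxymethyl group does. No step beyond the scatter is therefore expected in this assay. The expected step is a 1.0-fold lower number from compound 2 to compound 3 (0.00 log units; within the scatter). For compound 3 the estimated value is 13000 nM, with an expected range of 7000 nM to 22000 nM.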

Compound 3, half-maximal cytotoxic concentration: > 25000 nM
Compound 3: no number, only a limit (the forecaster's own chance of this, stated with the estimate: 25%); at least 1.9-fold (0.28 log units) between middle value and limit.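

Moving the hydroxymethyl group on the aromatic ring, with the same atoms joined differently, gives in this assay an at least 1.9-fold higher number from compound 2 to compound 3 (0.28 log units; that floor lies within the scatter). Compound 3 gives > 25000 nM, which is a limit of the assay and not a number; only a floor for the step is known, and that floor does not separate the pair. Among the compounds shown here, this is the first step that isolates the placement of the hydroxymethyl group, whereas the step from compound 1 to compound 3 swaps the whole substituent, rests on two limits and cannot be read.

Open, as far as these compounds go, is whether moving the group changes the reading in this assay by more than the usual scatter. Also open, from the compounds shown here alone, is how a carboxylic acid or an aminomethyl group would read in place of hydroxymethyl on the same aromatic ring.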